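This account rests on a few compounds, and the source may have more. Where it says the series, first, only, none or still open, it means among the compounds named here.

Measured in a functional assay on A549 cells (Homo sapiens) for antiproliferative activity, read by MTT assay, with a stated time of 72 h; on this read-out higher numbers stand for weaker inhibition and lower numbers for stronger inhibition:
- compound 1 `CC(C)/C=C/C(=O)Nc1cccc(Oc2nc(Nc3ccn(C)n3)nc3c2CSCC3)c1`: 33500 nM
- compound 2 `CC/C=C/C(=O)Nc1cccc(Oc2nc(Nc3ccc(OC)nc3)nc3c2CSCC3)c1`: 13100 nM
- compound 3 `CCC/C=C/C(=O)Nc1cccc(Oc2nc(Nc3ccc(OC)nc3)nc3c2CSCC3)c1`: 10800 nM

Compound 3, at 10800 nM, cannot be told apart from compound 2, while compound 1 stands clearly higher at 33500 nM.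

Compound 4 `COc1ccc(Nc2nc3c(c(Oc4cccc(NC(=O)/C=C/C(C)C)c4)n2)CSCC3)cn1` differs from compound 3 in one place: isopropyl in place of propyl on a double-bonded chain carbon bound to a double-bonded chain carbon. Among the compounds with values here, the one measured step on this chain, a 1.2-fold lower number from compound 2 to compound 3 (0.08 log units; within the scatter), added a methyl and stayed within the scatter. Compound 1 carries the same isopropyl but also differs elsewhere, so its value cannot isolate this change. In this assay, the expected step is small, a 1.2-fold higher number from compound 3 to compound 4 (0.06 log units; within the scatter), and not beyond the scatter. For compound 4 the estimated value is 12500 nM, with an expected range of 6000 nM to 26000 nM.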

Compound 4, half-maximal inhibitory concentration: 24200 nM
For compound 4 the middle estimate is 1.9-fold (0.29 log units) below the measured one; the measured number falls inside the stated range.
By their numbers in this assay, from the lowest: compounds 3, 2, 4 and 1 (each within the scatter of the next, the first and the last beyond it).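

In this assay, within the data shown here, the branching of the chain counts where the one earlier methyl step did not: isopropyl in place of propyl, with the same atoms joined differently, gives a 2.2-fold higher number from compound 3 to compound 4 (0.35 log units; beyond the scatter) as a modest loss. Set against compound 2, the same chain gives a 1.8-fold higher number from compound 2 to compound 4 (0.27 log units; within the scatter) and so no clear change. With isopropyl kept, 6-methoxypyridin-3-yl in place of 1-methyl-1H-pyrazol-3-yl gives a 1.4-fold lower number from compound 1 to compound 4 (0.14 log units; within the scatter) and also no clear change.

Going by these compounds, whether a longer chain or a chain carrying an amine would give a lower number than compound 3 stays open. No measurement here explains the branching step.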